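Swapping a Methoxy for an Amino on a Weak Binder

The compounds below may be only part of what the source reports. "The series", "measured", "known", "first", "only" and "open" are said of these compounds alone.

This small series was studied in an assay on isolated protein for binding affinity to Polycomb protein EED (Homo sapiens), read by surface plasmon resonance; on this read-out lower numbers stand for tighter binding and higher numbers for weaker binding. Three compounds were made and examined, but only one of them has a number attached. Compound 1 `Cc1cc(F)c(CNc2ncc(-c3cccnc3C)c3nncn23)c2c1OCC2` is recorded in this assay as "not determined" (no result reported), and compound 2 `Cc1ncccc1-c1cnc(NCc2c(F)cc(C3CC3)c3c2CCO3)n2cnnc12` is recorded in this assay as "not determined" (no result reported), so nothing can be said about how tightly either of them binds. Within the data shown here, compound 3 `COc1cc(F)c(CNc2ncc(-c3cccnc3C)c3nncn23)c2c1OCC2` is the one compound with a figure: in this assay compound 3 gives 305000 nM, which places it among the very weak binders, far from the range where a molecule would be called potent. With the other two entries lacking numbers, compound 3 stands alone and cannot be ranked against anything.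

The next compound, compound 4 `Cc1ncccc1-c1cnc(NCc2c(F)cc(N)c3c2CCO3)n2cnnc12`, differs from compound 3 in a single place: amino in place of methoxy on an aromatic carbon. Among the measured compounds shown here, no step between two measured compounds is available to show what such a swap does here, so the expectation rests on the weak starting point alone. Compound 4 is expected to sit in the same region as compound 3, with a step from a 1.2-fold lower number from compound 3 to compound 4 (0.09 log units; within the scatter) that is expected to stay within the scatter. Compound 4 is thus estimated at 250000 nM, with a range from 80000 nM to 800000 nM.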

Compound 4, dissociation constant: 500 nM
Compound 4: the middle estimate sits 500-fold (2.70 log units) above what was measured; the whole stated range lies above it.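

In this assay, the aromatic carbon ortho to a fused ring and meta to a fluoro group proves highly sensitive to what it carries: amino in place of methoxy gives a 610-fold lower number from compound 3 to compound 4 (2.79 log units; beyond the scatter) and lifts a very weak binder into a far tighter range. By count the edit is small, with methoxy taking 2 heavy atoms and 0 hydrogen-bond donors away and amino bringing 1 heavy atom and 1 hydrogen-bond donor, so a large shift in binding here needs no large change in structure. Nothing shown gives a measured reason for the size of this step.

The steps to compound 1, which has methyl at this position, and to compound 2, which has cyclopropyl there, cannot be read: neither compound has a result, so the picture at this position rests on two groups only. Whether the tighter binding is particular to amino also remains open, as the compounds shown have no hydroxyl or methylamino group at this position to set beside it.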